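Cytotoxicity notes on a side-chain series

The source may report more compounds than this note shows. Statements on the series, on what has been measured and on what is new or still open speak of the compounds shown alone.

Measured so far in an ADME assay on HEK293-A cells (Homo sapiens) for cytotoxicity, read by MTT assay, with a stated time of 48 h; on this read-out lower numbers stand for stronger inhibition and higher numbers for weaker inhibition:
compound 1 `O=C1O[C@@H](CN2CCC(O)CC2)CN1c1ccc(-n2cc(-c3ccccn3)cn2)c(F)c1` gives > 400 ug/mL, a limit of the assay.
compound 2 `O=C(OC[C@H]1CN(c2ccc(-n3cc(-c4ccccn4)cn3)c(F)c2)C(=O)O1)c1ccccc1` gives > 400 ug/mL, a limit of the assay.
compound 3 `CN(C)S(=O)(=O)NC[C@H]1CN(c2ccc(-n3cc(-c4ccccn4)cn3)c(F)c2)C(=O)O1` gives 249 ug/mL.

Compound 2 therefore stands at the limit of this assay, and no number is known for it; the same holds for compound 1, as the limit of > 400 ug/mL in this assay, at which 2 of the 3 values shown sit, records. Going by the values given here, compound 3 is the only measured member with a number.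

The unmeasured compound 4 `O=C1O[C@@H](CNC(=O)C(F)(F)F)CN1c1ccc(-n2cc(-c3ccccn3)cn2)c(F)c1` differs from compound 2 in one place: ((trifluoromethyl)carbonyl)amino in place of benzoyloxy on a saturated chain carbon bound to a saturated ring carbon.

Among the compounds with values here, two measured steps bear on this change. The step from compound 1 to compound 2, a step that the two limits leave unreadable from compound 1 to compound 2, says nothing about size. The step from compound 2 to compound 3, an at least 1.6-fold lower number from compound 2 to compound 3 (0.20 log units; that floor lies within the scatter), is a floor only, and that floor lies within the scatter; the parallel step an at least 1.6-fold lower number from compound 1 to compound 3 (0.20 log units; that floor lies within the scatter) reads the same. The exchange of benzoyloxy for a small, ring-free group thus gives, at most, a number near the limit. For compound 4 the expected step of an at least 1.0-fold lower number from compound 2 to compound 4 (0.03 log units; that floor lies within the scatter) in this assay is estimated to stay within the scatter, and most likely only a limit will again be reported. Compound 4 is estimated at 370 ug/mL, in the range 200 ug/mL to 400 ug/mL.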

Compound 4, half-maximal inhibitory concentration: > 400 ug/mL
Compound 4: no number, only a limit (the forecaster's own chance of this, stated with the estimate: 60%); at least 1.0-fold (0.03 log units) between middle value and limit.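

Going by these compounds alone, at this position, ((trifluoromethyl)carbonyl)amino, a group with no ring, now joins 4-hydroxypiperidin-1-yl and benzoyloxy without giving a number in this assay, so neither the ring of benzoyloxy nor the ring of 4-hydroxypiperidin-1-yl is needed for that outcome, and compound 3 is the one member that goes against the pattern. Within the data shown here, on an amine nitrogen, (trifluoromethyl)carbonyl in place of dimethylsulfamoyl gives an at least 1.6-fold higher number from compound 3 to compound 4 (0.20 log units; that floor lies within the scatter), which makes this the first comparison of two groups on that same nitrogen, though it remains a floor and cannot show a real gap between them. The steps among compound 1, compound 2 and compound 4 cannot be read, and the series now gathers almost entirely at one point of the scale: the limit of > 400 ug/mL in this assay, at which 3 of the 4 values shown sit.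

Going by these compounds, whether an acetyl or a methanesulfonyl group on an amine nitrogen, or a free primary amine on the saturated chain carbon, would give a number or again only a limit stays open. On these data alone, the true size of every step also stays open, as does whether any group at this position can bring the read-out clearly below the value of compound 3.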